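A few compounds are considered here, and "the series" means these few. Any claim that something is new, unique, unknown or untested is made for them only; others in the source may bear on it.

Compound 1 `CNC(=O)c1cc(C(=O)NC2CC2)cn(Cc2ccc(F)cc2)c1=O`: 84 ug/mL
Compound 2 `CNC(=O)c1cc(C(=O)NC2CC2)cn(Cc2cccc3[nH]ccc23)c1=O`: 17 ug/mL

In a physicochemical assay for solubility, read by HPLC, in simulated intestinal fluid, with a stated time of 16 h, tested at 125 ug/mL (on this read-out lower numbers stand for lower solubility and higher numbers for higher solubility), compound 1 gives 84 ug/mL and stands highest of the two numbers; its nearest neighbour is compound 2, which gives 17 ug/mL, the step being a 4.9-fold lower number from compound 1 to compound 2 (0.69 log units; beyond the scatter). Compound 3 `CNC(=O)c1cc(C(=O)NC2CC2)cn(Cc2cccc(OC)c2)c1=O` differs from compound 1 by 3-methoxyphenyl in place of 4-fluorophenyl on a saturated chain carbon bound to an aromatic nitrogen. Among the measured compounds shown here, the one measured step, from compound 1 to compound 2, concerns a different group entering at the same place, so it bears on compound 3 only loosely. For compound 3 a small step is expected, a 1.1-fold higher number from compound 1 to compound 3 (0.05 log units; within the scatter), within the scatter. Compound 3 is estimated at 95 ug/mL, between 45 ug/mL and 140 ug/mL.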

Compound 3, solubility: 582 ug/mL
Estimate against measurement, compound 3: 6.1-fold (0.79 log units) below; measured number outside the range, above it.
By their numbers in this assay, from the lowest: compound 2; then compound 1; then compound 3.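

At this place, on a saturated chain carbon bound to an aromatic nitrogen, a change can raise the number as well as lower it: 3-methoxyphenyl in place of 4-fluorophenyl gives a 6.9-fold higher number from compound 1 to compound 3 (0.84 log units; beyond the scatter) in this assay and 3-methoxyphenyl in place of 1H-indol-4-yl gives a 34-fold higher number from compound 2 to compound 3 (1.53 log units; beyond the scatter) on the same read-out. Compound 3 therefore stands highest of the three, with both steps beyond the scatter. Nothing measured here explains this. Whether the step goes with gaining the methoxy group or losing the fluorine stays open, as the compounds shown include no unsubstituted phenyl. On these data alone, how an amine or a carboxylic acid on that ring would read also remains open.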